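Methoxy Additions to the Phenyl Group of Compound 3

The source may report more compounds than this note shows. Statements on the series, on what has been measured and on what is new or still open speak of the compounds shown alone.

Compound 3 `COc1cc2c(Oc3ccc(NC(=O)c4cc(-c5ccccc5)ccn4)cc3F)ccnc2cc1OCCCN1CCCC1` is a close relative of compound 1 `COc1cc2c(Oc3ccc(NC(=O)c4cc(-c5ccccc5)ccn4)cc3F)ccnc2cc1OCCCN1CCN(C)CC1` and compound 2 `COc1cc2c(Oc3ccc(NC(=O)c4cc(-c5ccccc5F)ccn4)cc3F)ccnc2cc1OCCCN1CCN(C)CC1`. In a functional assay on MKN-45 cells (Homo sapiens) for cytotoxicity, read by MTT assay, with a stated time of 72 h (a lower number here means a stronger inhibitor, a higher number a weaker inhibitor), compound 1 gives 150 nM, compound 2 gives 150 nM, and compound 3 gives 210 nM. Among these three numbers compound 3 carries the highest, although its distance from the others, a 1.4-fold higher number from compound 1 to compound 3 (0.15 log units; within the scatter), lies within the scatter, so no ordering can be read from it. Compound 4 `COc1ccc(-c2ccnc(C(=O)Nc3ccc(Oc4ccnc5cc(OCCCN6CCCC6)c(OC)cc45)c(F)c3)c2)c(OC)c1` differs from compound 3 by 2,4-dimethoxyphenyl in place of phenyl on an aromatic carbon. Within the data shown here, only one measured step touches the phenyl group: no change at the digits printed from compound 1 to compound 2 (within the scatter), which showed nothing beyond the scatter. The other step, a 1.4-fold higher number from compound 1 to compound 3 (0.15 log units; within the scatter), concerns a different part of the molecule. Among the measured compounds shown here, neither step speaks directly to methoxy groups, since no measured compound carries them. At most a small step is therefore expected in this assay, with no firm direction, and the step is estimated as a 1.2-fold higher number from compound 3 to compound 4 (0.08 log units; within the scatter). Compound 4 is accordingly expected to give about 250 nM in this assay, within a range from 100 nM to 650 nM.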

Compound 4, half-maximal inhibitory concentration: 740 nM
Beside the measured number, compound 4's estimate is 3.0-fold (0.47 log units) below it; measured number above the stated range.
By their numbers in this assay, from the lowest: compounds 1, 2 and 3 (each within the scatter of the next); then compound 4.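

In this assay the group on the aromatic carbon opposite the ring nitrogen turns out to be open to change, since 2,4-dimethoxyphenyl in place of phenyl gives a 3.5-fold higher number from compound 3 to compound 4 (0.55 log units; beyond the scatter) and so a step beyond the scatter. Among these compounds, the only earlier change on this phenyl group, a fluoro in place of a hydrogen, gave no change at the digits printed from compound 1 to compound 2 (within the scatter) and so showed no such sensitivity, although it was read with 4-methylpiperazin-1-yl on the chain rather than pyrrolidin-1-yl. Nothing at hand accounts for the step.

The compounds shown leave open whether a single methoxy group on the phenyl group would give a step of this size, or whether both are needed. They also leave open how an amine or a carboxylic acid on this phenyl group would read, and whether the step holds with 4-methylpiperazin-1-yl on the chain.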